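The source may report more compounds than this note shows. Statements on the series, on what has been measured and on what is new or still open speak of the compounds shown alone.

Measured in an ADME assay on microsomes from liver (Homo sapiens) for metabolic stability, read by LC-MS; a lower number here means that the compound disappears faster, a higher number that the compound lasts longer:
- compound 1 `O=C(Nc1ccc(F)c(-c2nc3ncc(-c4ccc(F)c(F)c4)cc3[nH]2)c1)N1CCCC1`: 0.282 h
- compound 2 `Cc1nc(C)c(C(=O)Nc2ccc(F)c(-c3nc4ncc(-c5cccnc5Cl)cn4n3)c2)o1`: > 1.5 h
- compound 3 `O=C(Nc1ccc(F)c(-c2nc3ncc(-c4ccc(F)cc4)cc3[nH]2)c1)N1CCCC1`: 0.203 h

Compound 3, at 0.203 h, shares the low end of these numbers with compound 1, the two lying within the scatter of each other. For compound 2 the result, > 1.5 h, is a limit and not a number.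

Compound 4 `O=C(Nc1ccc(F)c(-c2nc3ncc(-c4cccnc4F)cc3[nH]2)c1)N1CCCC1` takes 2-fluoropyridin-3-yl in place of 4-fluorophenyl on an aromatic carbon of the shared core: 2-fluoropyridin-3-yl in place of 4-fluorophenyl on an aromatic carbon. Among the compounds with values here, one measured step touches the same group, a 1.4-fold lower number from compound 1 to compound 3 (0.14 log units; within the scatter), where hydrogen replaces fluoro on an aromatic carbon. That step stays within the scatter, but it leaves the ring atoms untouched, so it bears only loosely on the new change. Compound 2 also has a ring nitrogen in its aryl group, yet it differs from compound 3 in several other places and offers no more than a faint hint of an upward direction. A small rise, near the edge of the scatter, is therefore expected, and a large one is not. The expected step is a 1.6-fold higher number from compound 3 to compound 4 (0.20 log units; within the scatter). For compound 4 the estimated half-life is 0.32 h, with an expected range of 0.15 h to 0.75 h.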

Compound 4, half-life: > 1.5 h
Compound 4 ended at the assay's limit; the forecaster's own chance of this, stated with the estimate: 3%; at least 4.6-fold (0.67 log units) between middle value and limit.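

In this assay, this position on the shared core proves able to carry a step beyond the scatter, which the swap of fluoro for hydrogen on the same aryl group had not shown. Placing 2-fluoropyridin-3-yl on this aromatic carbon in place of 4-fluorophenyl gives an at least 7.3-fold higher number from compound 3 to compound 4 (0.86 log units; beyond the scatter), and placing it there in place of 3,4-difluorophenyl gives an at least 5.3-fold higher number from compound 1 to compound 4 (0.72 log units; beyond the scatter). The true size of both steps remains unknown because the result for compound 4 is a limit and not a number: the limit of > 1.5 h in this assay, at which 2 of the 4 values shown sit.

The change brings in a ring nitrogen and a differently placed fluoro together, and the compounds shown do not separate the two. On these data alone, what a plain pyridin-3-yl or a 2-methoxypyridin-3-yl would give at this position on the same core remains open, as does how far past its limit compound 4 lies.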